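From a Fluoro to a Methyl: Estimating Compound 3

The source may report more compounds than this note shows. Statements on the series, on what has been measured and on what is new or still open speak of the compounds shown alone.

Measured so far in a functional assay on SK-OV-3 cells (Homo sapiens) for cytotoxicity, read by MTT assay, with a stated time of 48 h; a higher number here means a weaker inhibitor, a lower number a stronger inhibitor:
compound 1 `O=C(/C=C/c1ccc2c(c1)B(O)OC2)c1cccnc1` gives 18500 nM
compound 2 `O=C(/C=C/c1ccc2c(c1)B(O)OC2)c1cccc(F)c1` gives 4800 nM

Compound 2 stands lowest of the two numbers in this assay; the only gap shown is a 3.9-fold lower number from compound 1 to compound 2 (0.59 log units; beyond the scatter). That single step exchanges the whole ring on the carbonyl carbon, a different kind of change from the one now considered. Compound 3 `Cc1cccc(C(=O)/C=C/c2ccc3c(c2)B(O)OC3)c1` differs from compound 2 by methyl in place of fluoro on an aromatic carbon. No measured step swaps one small substituent for another on that ring, so nothing shown speaks to the size or direction of this change. Compound 3 is therefore expected to sit close to compound 2, with a step of a 1.1-fold lower number from compound 2 to compound 3 (0.03 log units; within the scatter) that stays within the scatter. The estimate for compound 3 in this assay is 4500 nM, with a range from 1800 nM to 11000 nM.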

Compound 3, half-maximal inhibitory concentration: 2900 nM
Beside the measured number, compound 3's estimate is 1.6-fold (0.19 log units) above it; measured number inside the range.
By their numbers in this assay, from the lowest: compounds 3 and 2 (each within the scatter of the next); then compound 1.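

In this assay the exchange of fluoro for methyl at this place gives a 1.7-fold lower number from compound 2 to compound 3 (0.22 log units; within the scatter), so the two small groups are not told apart here. The step of a 6.4-fold lower number from compound 1 to compound 3 (0.80 log units; beyond the scatter) now stands with a 3.9-fold lower number from compound 1 to compound 2 (0.59 log units; beyond the scatter), and both lie beyond the scatter: the gain over the pyridin-3-yl ring of compound 1 is seen with 3-methylphenyl as well as with 3-fluorophenyl, and so does not rest on the fluoro group alone. Nothing measured here offers an explanation for either step.

As far as these compounds go, whether an amine or a carboxylic acid on this ring would keep the number in the same range remains open. So does the outcome of a longer chain in place of the methyl, or of either group at another place on the ring.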